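Ethyl ester step from compound 3 to compound 4

The source may report more compounds than this note shows. Statements on the series, on what has been measured and on what is new or still open speak of the compounds shown alone.

Measured in a functional assay on a cell-free system (Platelet, plasma, Oryctolagus cuniculus) for inhibition, with a stated time of 5 min, at 37 degrees C; a lower number here means a stronger inhibitor, a higher number a weaker inhibitor:
- compound 1 `COc1cc(/C=C/C(=O)O)ccc1OC(=O)c1nc(C)c(C)nc1C`: 44600 nM
- compound 2 `CCOC(=O)/C=C/c1ccc(OC(=O)c2nc(C)c(C)nc2C)c(O)c1`: 77400 nM
- compound 3 `COc1cc(/C=C/C(=O)O)cc(OC)c1OC(=O)c1nc(C)c(C)nc1C`: 82300 nM

Compound 3, at 82300 nM, lies within the scatter of both compound 1 and compound 2, so the three values show no order. The next structure is compound 4 `CCOC(=O)/C=C/c1cc(OC)c(OC(=O)c2nc(C)c(C)nc2C)c(OC)c1`, and the change from compound 3 is ethyl in place of hydrogen on an oxygen next to a carbonyl group, which reads as carboxy to ethoxycarbonyl.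

Within the data shown here, the one measured step, a 1.8-fold higher number from compound 1 to compound 3 (0.27 log units; within the scatter), is a different change, methoxy in place of hydrogen on an aromatic carbon, and it stays within the scatter. Among the measured compounds shown here, no measured pair isolates the ester change itself. Compound 2 already carries ethoxycarbonyl but also differs from the other two elsewhere on the core, and its value of 77400 nM falls in the same band as compound 1 and compound 3.

No shift beyond the scatter is therefore expected in this assay, in either direction. The expected step is a 1.1-fold lower number from compound 3 to compound 4 (0.04 log units; within the scatter). The estimate for compound 4 is 75000 nM. The expected range for compound 4 runs from 32000 nM to 170000 nM.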

Compound 4, half-maximal inhibitory concentration: 37500 nM
Estimate against measurement, compound 4: 2.0-fold (0.30 log units) above; low and high end bracket the measured number.
By their numbers in this assay, from the lowest: compounds 4, 1, 2 and 3 (each within the scatter of the next, the first and the last beyond it).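

In this assay there is a 2.2-fold lower number from compound 3 to compound 4 (0.34 log units; beyond the scatter) when ethyl takes the place of hydrogen on an oxygen next to a carbonyl group, the change from carboxy to ethoxycarbonyl. Among these compounds, this is the first step to lie beyond the scatter, and it shows that on this core a free carboxy group is not required for inhibition, as the ester gives the lower number of the pair. Nothing available here bears on the cause of this step.

Whether the step is specific to ethyl stays open, since a methyl ester, a longer chain such as butyl on the same oxygen, and an amide are not among the compounds shown. The same change on the core of compound 1 also stays open, as no ethyl ester of compound 1 is shown.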